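The source may hold more compounds than are shown below. What is called first, only, known or untested is meant among the compounds shown, and "the series" means these compounds.

Measured so far:
compound 1, `Cc1nc(-c2ccccc2)c(CNCCCN2CCN(c3ccc(Cl)cc3)CC2)o1`, gives 38.1% in an assay on HEK293 cells for inhibition of Voltage-dependent T-type calcium channel subunit alpha-1G (Homo sapiens), read by fluorescence, tested at 10 uM; on this read-out lower numbers stand for less inhibition and higher numbers for more inhibition at the one concentration tested (going by the name of the read-out)
compound 2, `CCCc1nc(-c2ccccc2)c(CNCCCN2CCN(c3ccccc3C)CC2)o1`, gives 54.5% in this assay

Compound 2 stands highest of the two numbers; its nearest neighbour is compound 1, which lies lower by a gap beyond the usual scatter. The two differ in more than one place, so no single step can be read from them.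

Compound 3, `CCCc1nc(-c2ccccc2)c(CNCCCN2CCN(c3ccc(Cl)cc3)CC2)o1`, is not yet measured. It differs from compound 2 in one place: 4-chlorophenyl in place of 2-methylphenyl on an amine nitrogen in a ring. The 4-chlorophenyl it carries is the same group found in compound 1, while the rest of compound 3 matches compound 2. Without a single-change step to lean on, the size of the step in this assay is open; a drop towards the value of compound 1 is plausible, but a step within the scatter cannot be excluded.

For compound 3 the expected result in this assay is 45%, within 25% to 65%, which means an expected step of a number 9.5 percentage points lower from compound 2 to compound 3 (within the scatter).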

Compound 3, a percentage reported as inhibition, at one concentration (the size of the read-out at that concentration, not a potency): 63.3%
Compound 3: the middle estimate sits 18.3 percentage points below what was measured, and the stated range covers the measured number.
By their numbers in this assay, from the lowest: compound 1; then compounds 2 and 3 (each within the scatter of the next).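

In this assay, 4-chlorophenyl in place of 2-methylphenyl on an amine nitrogen in a ring gives a number 8.8 percentage points higher from compound 2 to compound 3 (within the scatter), so these two groups cannot be told apart at this position. With 4-chlorophenyl held constant, ethyl in place of hydrogen on a saturated chain carbon bound to an aromatic carbon gives a number 25.2 percentage points higher from compound 1 to compound 3 (beyond the scatter), so the gap in this small set goes with the chain rather than with the group on the ring nitrogen. Nothing measured here bears on the cause of either step.

The compounds shown leave open whether a 2-chlorophenyl or a 4-methylphenyl on the same nitrogen would separate the kind of substituent from where it sits on the phenyl ring. Also open, from the compounds shown here alone, is whether a longer chain, such as butyl, would carry the trend further.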